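Trimming the Sulfonamide Side Chain of a Potent Antagonist

The compounds below may be only part of what the source reports. "The series", "measured", "known", "first", "only" and "open" are said of these compounds alone.

Of the compounds shown here, three have been measured in an assay on CHO cells for displacement of a labelled ligand from prostaglandin D2 receptor 2 (Homo sapiens), read by scintillation counting; on this read-out lower numbers stand for stronger inhibition and higher numbers for weaker inhibition. Compound 1 `COCCN(C)S(=O)(=O)c1ccc(C)c(C#Cc2cc(Cl)ccc2OCC(=O)O)c1` gives 4.1 nM in this assay, the lowest of the three numbers. Compound 2 `O=C(O)COc1ccc(Cl)cc1C#Cc1ccccc1Cl` gives 28 nM, and compound 3 `CCCS(=O)(=O)c1cccc(C#Cc2c(OCC(=O)O)cccc2-c2sc(C)nc2C)c1` gives 54 nM. Both gaps away from compound 1 lie beyond the scatter of repeated measurements, so compound 1 is the most potent of the set; the gap to compound 2 is the smaller one and the gap to compound 3 the larger one.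

Compound 4 `Cc1ccc(S(=O)(=O)N(C)C)cc1C#Cc1cc(Cl)ccc1OCC(=O)O` has not yet been measured. It differs from compound 1 in a single place: hydrogen in place of methoxymethyl on a saturated chain carbon bound to a sulfonamide nitrogen. The shared core, the chlorine and the acid-bearing side chain are unchanged. Among the compounds with values here, no measured pair in this set shows what removing the methoxymethyl piece does to the binding number, so the expectation rests only on the small size of the change and on where compound 1 stands.

Since compound 1 sits at 4.1 nM, the step of a 1.7-fold higher number from compound 1 to compound 4 (0.23 log units; within the scatter) is expected to be small, at most a mild weakening and possibly within the scatter. Compound 4 is therefore estimated at 7 nM, with a range from 2.5 nM to 20 nM.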

Compound 4, inhibition constant: 5 nM
Beside the measured number, compound 4's estimate is 1.4-fold (0.15 log units) above it, within the range that was stated.
By their numbers in this assay, from the lowest: compounds 1 and 4 (each within the scatter of the next); then compounds 2 and 3 (each within the scatter of the next).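

Cutting (2-methoxyethyl)(methyl)sulfamoyl back to dimethylsulfamoyl gives the first step in this set that differs in one place only, and it reads as a 1.2-fold higher number from compound 1 to compound 4 (0.09 log units; within the scatter) in this assay for this single change. This shows that, at this position, the methoxymethyl piece on a saturated chain carbon bound to a sulfonamide nitrogen can be replaced by hydrogen without a difference that this measurement can separate from ordinary scatter, so compound 1 and compound 4 cannot be told apart here, and the smaller group serves as well as the larger one in this pair. Nothing measured here speaks to why the two numbers lie so close.

The compounds shown hold only this one step on the sulfonamide nitrogen, so they give no reading for a longer chain there, or for a chain that ends in an amine or a carboxylic acid. They also leave open what happens if a methyl on that nitrogen is replaced by hydrogen, and whether the same trimming would read the same way on a different core.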